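Dropping the chloro: expected toxicity of compound 3

This account rests on a few compounds, and the source may have more. Where it says the series, first, only, none or still open, it means among the compounds named here.

Compound 1, `COc1ccc(OC)c(/C=C/c2nnc(Nc3ccc(Cl)cc3)o2)c1`: > 100000 nM
Compound 2, `COc1ccc(OC)c(/C=C/C(=O)N/N=C/c2ccc(Cl)cc2)c1`: > 100000 nM

Both of these values are limits of a functional assay on M14 cells (Homo sapiens) for antiproliferative activity, read by sulforhodamine B assay, with a stated time of 48 h (on this read-out lower numbers stand for higher toxicity in this test and higher numbers for lower toxicity in this test), not numbers. Compound 2 therefore stands at the limit, together with the other value shown (the limit of > 100000 nM in this assay, at which 2 of the 2 values shown sit). Compound 3, `COc1ccc(OC)c(/C=C/C(=O)N/N=C/c2ccccc2)c1`, differs from compound 2 by hydrogen in place of chloro on an aromatic carbon. For the measured compounds named here, no measured step is available for this change, so in this assay no step beyond the usual scatter is expected in either direction. Compound 3 is estimated at 150000 nM, between 50000 nM and 500000 nM. The expected step is a step that the limit leaves unreadable from compound 2 to compound 3.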

Compound 3, concentration lethal to 50% of the cells: > 100000 nM
Compound 3: no number, only a limit; the forecaster's own chance of this, stated with the estimate: 85%; the middle value is on the limit's open side.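

In this assay, compound 2 and compound 3 both give limits rather than numbers, so no step can be read between them. The compounds shown leave open whether going from 4-chlorophenyl to phenyl changes toxicity at all: the limit of > 100000 nM in this assay, at which 3 of the 3 values shown sit.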